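Replacing the 2-fluorophenyl of compound 1 with butyl

The compounds below may be only part of what the source reports. "The series", "measured", "known", "first", "only" and "open" are said of these compounds alone.

Compound 1 `CC1(C)C(=O)Nc2nc(-n3nc(Cc4ccccc4F)c4cc(Cl)ccc43)nc(N)c21` is the weakest of the three measured compounds in an assay on CHO cells for activation of soluble guanylate cyclase alpha1/beta1 complex (Homo sapiens), read by cGMP accumulation (on this read-out lower numbers stand for an effect already at smaller amounts and higher numbers for an effect only at larger amounts of compound), giving 18000 nM. Compound 2 `CC1(C)C(=O)Nc2nc(-n3nc(Cc4ccccc4F)c4ccccc43)nc(N)c21` gives 3000 nM in this assay, and compound 3 `COC(=O)N(C)c1c(N)nc(-n2nc(Cc3ccccc3F)c3cc(F)ccc32)nc1N`, on a different core, gives 960 nM. Within the data shown here, the only single-point step, a 6.0-fold lower number from compound 1 to compound 2 (0.78 log units; beyond the scatter), concerns hydrogen in place of chloro on an aromatic carbon and does not touch the group changed here. Compound 4 `CCCCCc1nn(-c2nc(N)c3c(n2)NC(=O)C3(C)C)c2ccc(Cl)cc12` differs from compound 1 by butyl in place of 2-fluorophenyl on a saturated chain carbon bound to an aromatic carbon. Among the measured compounds shown here, no measured pair shows this change, so no step size can be read from the data for it. The number for compound 4 is therefore expected to stay near that of compound 1, a 1.4-fold higher number from compound 1 to compound 4 (0.14 log units; within the scatter), with wide uncertainty. Compound 4 is estimated at 25000 nM, within 5000 nM to 100000 nM in this assay.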

Compound 4, half-maximal effective concentration: 90000 nM
Estimate against measurement, compound 4: 3.6-fold (0.56 log units) below, within the range that was stated.
By their numbers in this assay, from the lowest: compound 3; then compound 2; then compound 1; then compound 4.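

At this position, on a saturated chain carbon bound to an aromatic carbon, butyl in place of 2-fluorophenyl gives a 5.0-fold higher number from compound 1 to compound 4 (0.70 log units; beyond the scatter) in this assay. Among these compounds, this is the first read on this place: the group held there does move the number, and on the core of compound 1 the open chain does not match the 2-fluorophenyl ring. Nothing measured here accounts for the step. Going by these compounds, whether a cyclohexyl or a longer chain would follow butyl or 2-fluorophenyl remains open. Also open, on these data alone, is whether the step carries over to the core of compound 3.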